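The source may hold more compounds than are shown below. What is called first, only, known or untested is meant among the compounds shown, and "the series" means these compounds.

In an ADME assay (liver) for pharmacokinetics, with Liver microsome (Homo sapiens) as the target, using microsomes (a higher number here means that the compound lasts longer, a lower number that the compound disappears faster), compound 1 `CCOc1cc(NC(=O)C2(NC(=O)c3ccc4c(C5CCCC5)c(-c5ncc(Cl)cn5)n(C)c4c3)CCC2)ccc1/C=C/C(=O)OC(=O)C[C@H](O)C(=O)O` gives 5.57 h. Compound 2 `CCOc1cc(NC(=O)C2(NC(=O)c3ccc4c(C5CCCC5)c(-c5ncc(Cl)cn5)n(C)c4c3)CCC2)ccc1/C=C/C(=O)OCC(C)C` reaches only a limit of the assay, > 5 h. Compound 3 `CCOc1cc(NC(=O)C2(NC(=O)c3ccc4c(C5CCCC5)c(-c5ncc(Cl)cn5)n(C)c4c3)CCC2)ccc1/C=C/C(=O)OCc1ccccc1` likewise reaches only a limit, > 5 h. Because of this, a step that the limit leaves unreadable from compound 1 to compound 2 and a step that the limit leaves unreadable from compound 1 to compound 3 cannot be read, and a step that the two limits leave unreadable from compound 2 to compound 3 cannot be read either; what remains is the limit of > 5 h in this assay, at which 2 of the 3 values shown sit. Compound 4 `CCOc1cc(NC(=O)C2(NC(=O)c3ccc4c(C5CCCC5)c(-c5ncc(Cl)cn5)n(C)c4c3)CCC2)ccc1/C=C/C(=O)OCCOCCOC` has not yet been measured. It differs from compound 3 by (2-methoxyethoxy)methyl in place of phenyl on a saturated chain carbon bound to an oxygen next to a carbonyl group. Among the measured compounds shown here, the three measured steps, all hidden by the limit, give no size from which this step could be read; they show only that compounds 1, 2 and 3 sit at or around the same limit, whichever ester group stands on the oxygen next to the carbonyl group. Compound 4 is therefore expected to show a number no higher from compound 3 to compound 4 (the limit leaves the size open) in this assay, that is, no step beyond the scatter. The estimate for compound 4 is 5 h, with a range from 2.5 h to 10 h.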

Compound 4, half-life: 0.85 h
The estimate for compound 4 lay 5.9-fold (0.77 log units) above the measured number; measured number below the stated range.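

In this assay, the group on the oxygen next to a carbonyl group proves able to move the number, with an at least 5.8-fold lower number from compound 3 to compound 4 (0.76 log units; beyond the scatter) and an at least 5.8-fold lower number from compound 2 to compound 4 (0.76 log units; beyond the scatter). Against compound 1, 2-(2-methoxyethoxy)ethyl in place of (2-carboxy-2-hydroxyethyl)carbonyl gives a 6.6-fold lower number from compound 1 to compound 4 (0.82 log units; beyond the scatter), the only one of these steps with a fully readable size. The steps among compound 1, compound 2 and compound 3 still cannot be read, and the earlier picture of a shared level rests only on this limit: the limit of > 5 h in this assay, at which 2 of the 4 values shown sit.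

The compounds shown do not tell whether the lower number follows the oxygens of the 2-(2-methoxyethoxy)ethyl chain or its length, a question on which a hexyl ester would bear. From the compounds shown here alone, how a shorter 2-methoxyethyl ester, or an amine at the end of the chain, would read in this assay also stays open.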